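This account rests on a few compounds, and the source may have more. Where it says the series, first, only, none or still open, it means among the compounds named here.

Compound 1 `CO[C@H]1O[C@H](COc2ccc(OC3CCCCC3)cc2)[C@@H](O)[C@H](O)[C@H]1Oc1ccc(C(C)C)cc1` is the better of the two measured compounds in a functional assay on A549 cells (Homo sapiens) for cytotoxicity, read by MTT assay, with a stated time of 48 h (a lower number here means that less compound is needed, a higher number that more compound is needed for the effect), only in a nominal sense: compound 1 gives 27000 nM, and compound 2 `CO[C@H]1O[C@H](COc2ccc(-c3ccccc3)cc2)[C@@H](O)[C@H](O)[C@H]1Oc1ccc(C(C)C)cc1` gives 32000 nM, so the step of a 1.2-fold higher number from compound 1 to compound 2 (0.07 log units; within the scatter) shows the two within scatter. Compound 3 `CO[C@@H]1O[C@H](COc2ccc(OC3CCCCC3)cc2)[C@@H](O)[C@H](O)[C@H]1Oc1ccc(C(C)C)cc1` differs from compound 1 as follows: the two compounds have the same atoms and bonds and differ only in configuration as drawn: 1 of 5 stereo elements differ; a stereocentre at a saturated ring carbon is drawn S in compound 1 and R in compound 3. Among the compounds with values here, no measured step involves a change of configuration alone, so nothing here speaks for a shift in either direction, and the expected step of a 1.1-fold higher number from compound 1 to compound 3 (0.05 log units; within the scatter) is put at none beyond the scatter. Compound 3 is therefore estimated at 30000 nM, within a range of 12000 nM to 75000 nM.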

Compound 3, half-maximal effective concentration: 32000 nM
For compound 3 the middle estimate is 1.1-fold (0.03 log units) below the measured one; the range from low to high includes it.
By their numbers in this assay, from the lowest: compounds 1, 2 and 3 (each within the scatter of the next).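

The earlier compounds shown here held no change of configuration alone; for this stereocentre at a saturated ring carbon, this assay now gives a 1.2-fold higher number from compound 1 to compound 3 (0.07 log units; within the scatter). The comparison is a clean one, with a single thing separating the pair: the fact that compounds 1 and 3 differ only in the configuration as drawn. In this assay, then, the configuration drawn at this carbon does not separate the two compounds beyond the scatter.

As far as these compounds go, it remains open whether the same change of configuration would read alike with phenyl in place of cyclohexyloxy. From the compounds shown here alone, it also remains open whether an amine or a carboxylic acid in that place would move the number beyond the scatter.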